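A few compounds are considered here, and "the series" means these few. Any claim that something is new, unique, unknown or untested is made for them only; others in the source may bear on it.

Measured compounds:
compound 1 `Cc1c(C(=O)N/N=C\c2ccc(O)cc2)oc2cccc(O)c12`, 21700 nM
compound 2 `Cc1c(C(=O)N/N=C\c2cc([N+](=O)[O-])ccc2O)oc2cccc(O)c12`, 17100 nM

In a functional assay on PC-3 cells (Homo sapiens) for inhibition (on this read-out higher numbers stand for weaker inhibition and lower numbers for stronger inhibition), compound 1 gives 21700 nM, and compound 2 gives 17100 nM; the two numbers lie within the usual scatter of each other, so neither can be ranked against the other, and both show only weak inhibition. Compound 3 `Cc1c(C(=O)N/N=C\c2ccco2)oc2cccc(O)c12` has not yet been measured. It differs from compound 1 in one place: furan-2-yl in place of 4-hydroxyphenyl on a carbon with a double bond to nitrogen. Going by the values given here, no measured pair shows this change, so only an expectation is possible. Compound 3 is expected to give 30000 nM in this assay, within 10000 nM to 90000 nM. The estimated step of a 1.4-fold higher number from compound 1 to compound 3 (0.14 log units; within the scatter) is small and may well stay within the scatter.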

Compound 3, half-maximal inhibitory concentration: >= 40000 nM
Compound 3: no number, only a limit; the forecaster's own chance of this, stated with the estimate: 25%; middle value at least 1.3-fold (0.12 log units) from the limit.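

In this assay, furan-2-yl in place of 4-hydroxyphenyl on a carbon with a double bond to nitrogen gives an at least 1.8-fold higher number from compound 1 to compound 3 (0.26 log units; that floor lies within the scatter). For compound 3 the reading is a limit of the assay and not a number: the limit of >= 40000 nM in this assay, at which 1 of the 3 values shown sits. Going by these compounds, this change at this position thus brings no gain in inhibition, though the true size of the step stays unknown.

The compounds shown leave open whether an amine, a carboxylic acid or a longer chain on this carbon would give stronger inhibition than 4-hydroxyphenyl does.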